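Replacing (Pyridin-2-yl)oxy with Methylsulfanyl in Compound 1

A few compounds are considered here, and "the series" means these few. Any claim that something is new, unique, unknown or untested is made for them only; others in the source may bear on it.

Compound 1 `OC[C@H]1O[C@@H](n2cnc3c(COc4ccccn4)ncnc32)[C@H](O)[C@@H]1O` was run in a functional assay on Huh-7 cells (Homo sapiens) for cytotoxicity, read by MTT assay, with a stated time of 3 days; on this read-out higher numbers stand for lower toxicity in this test and lower numbers for higher toxicity in this test. In this assay compound 1 gives only a limit, > 250000 nM, so its exact position is not pinned down. Two compounds sharing its core were measured: compound 2 `CN(Cc1ccccc1)Cc1ncnc2c1ncn2[C@@H]1O[C@H](CO)[C@@H](O)[C@H]1O` gives 9000 nM, and compound 3 `O=C1CCCN1Cc1ncnc2c1ncn2[C@@H]1O[C@H](CO)[C@@H](O)[C@H]1O` gives 45000 nM. Both departures from compound 1 lower the number beyond the scatter: an at least 27-fold lower number from compound 1 to compound 2 (1.44 log units; beyond the scatter) and an at least 5.5-fold lower number from compound 1 to compound 3 (0.74 log units; beyond the scatter); between the two, a 5.0-fold higher number from compound 2 to compound 3 (0.70 log units; beyond the scatter). Compound 4 `CSCc1ncnc2c1ncn2[C@@H]1O[C@H](CO)[C@@H](O)[C@H]1O` differs from compound 1 by methylsulfanyl in place of (pyridin-2-yl)oxy on a saturated chain carbon bound to an aromatic carbon. Because an at least 27-fold lower number from compound 1 to compound 2 (1.44 log units; beyond the scatter) and an at least 5.5-fold lower number from compound 1 to compound 3 (0.74 log units; beyond the scatter) both point downward from the limit (the limit of > 250000 nM in this assay, at which 1 of the 3 values shown sits), a lower number is expected for compound 4 as well, though its size is uncertain. Compound 4 is estimated at 100000 nM, within 30000 nM to 250000 nM. This expected step is an at least 2.5-fold lower number from compound 1 to compound 4 (0.39 log units; beyond the scatter).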

Compound 4, half-maximal cytotoxic concentration: > 100000 nM
Compound 4: only a limit was reported; the forecaster's own chance of this, stated with the estimate: 35%; the middle value sits exactly at the limit.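

In this assay compound 4 gives > 100000 nM, which is a limit and not a number. Methylsulfanyl, which has no ring, leaves the number clearly higher than either of the two groups measured exactly: an at least 2.2-fold higher number from compound 3 to compound 4 (0.34 log units; beyond the scatter), and an at least 11-fold higher number from compound 2 to compound 4 (1.04 log units; beyond the scatter). Compound 1 also carries only a limit, and the step between it and compound 4 cannot be read.

Still open, as far as these compounds go, is whether methoxy or a plain amine on this saturated chain carbon would keep the number as high as methylsulfanyl does, or lower it towards compound 2.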